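This account rests on a few compounds, and the source may have more. Where it says the series, first, only, none or still open, it means among the compounds named here.

In a functional assay on Bel-7402 cells (Homo sapiens) for inhibition, read by MTT assay, with a stated time of 24 h, tested at 100 ug/mL (on this read-out higher numbers stand for more inhibition of growth at the one concentration tested and lower numbers for less inhibition of growth), compound 1 (`O=C(CCCCC1CCSS1)Nc1cccc(C(F)(F)F)c1`) gives 61.9% and compound 2 (`O=C(CCCCC1CCSS1)Nc1ccc(OC(F)(F)F)cc1`) gives 78.4%. Compound 1 is therefore the lower of the two, by a gap beyond the scatter. Compound 3 (`O=C(CCCCC1CCSS1)Nc1ccc([N+](=O)[O-])c(C(F)(F)F)c1`) has nitro in place of hydrogen on an aromatic carbon of compound 1, ortho to a trifluoromethyl group and para to a large group: nitro in place of hydrogen on an aromatic carbon. Among the measured compounds shown here, no measured step covers this change, so only a small rise within the scatter is expected in this assay. The expected size is a number 6.1 percentage points higher from compound 1 to compound 3 (within the scatter). For compound 3 the estimated value is 68%, with a range of 50% to 84%.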

Compound 3, percent growth inhibition at one concentration: 23.9%
For compound 3 the middle estimate is 44.1 percentage points above the measured one, and the stated range ends above it.
By their numbers in this assay, from the lowest: compound 3; then compound 1; then compound 2.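

In this assay the change is a large loss, a number 38 percentage points lower from compound 1 to compound 3 (beyond the scatter), with nitro in place of hydrogen on an aromatic carbon, ortho to a trifluoromethyl group and para to a large group. Among the compounds shown here, this position on the ring of compound 1 is therefore sensitive to substitution, which compound 1 and compound 2 could not show, since they offered no step in one place. Nothing available bears on the reason for this drop.

On these data alone, whether an amine or a methoxy group in the same place would give a similar loss remains open. Also open, as far as these compounds go, is whether nitro gives this step without the trifluoromethyl group.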